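A few compounds are considered here, and "the series" means these few. Any claim that something is new, unique, unknown or untested is made for them only; others in the source may bear on it.

Measured compounds in a functional assay on A549 cells (Homo sapiens) for antiproliferative activity, read by MTT assay, with a stated time of 48 h; a lower number here means a stronger inhibitor, a higher number a weaker inhibitor:
Compound 1 `O=c1cc(-c2ccccc2)oc2cc(OCc3ccccc3)c(OCCCCN3CCCCC3)c(O)c12` gives 1900 nM.
Compound 2 `O=c1cc(-c2ccccc2)oc2cc(OCc3ccccc3)c(OCCCN3CCCC3)c(O)c12` gives 1400 nM.
Compound 3 `CN1CCN(CCCOc2c(OCc3ccccc3)cc3oc(-c4ccccc4)cc(=O)c3c2O)CC1` gives 1300 nM.

Compound 3 gives the lowest of these three numbers, but none of the three is separated from another by more than the scatter, so the set describes a flat stretch rather than a ranking. The three compounds differ only in the amine that terminates the chain: the step of a 1.4-fold lower number from compound 1 to compound 2 (0.13 log units; within the scatter), the step of a 1.5-fold lower number from compound 1 to compound 3 (0.16 log units; within the scatter) and the step of a 1.1-fold lower number from compound 2 to compound 3 (0.03 log units; within the scatter) are all small.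

Compound 4 `CN(C)CCCOc1c(OCc2ccccc2)cc2oc(-c3ccccc3)cc(=O)c2c1O` continues this series with dimethylamino in place of 4-methylpiperazin-1-yl on a saturated chain carbon, three bonds along the chain from an oxygen on an aromatic ring. All three measured steps bear on this change, since each of them also exchanges one amine for another at the same place on the chain, and each stayed within the scatter. On that basis no step beyond the scatter is expected in this assay , in either direction, although the dimethylamino group is the only acyclic amine in the set, so the measured steps cover it less directly. Compound 4 is therefore expected to give 1600 nM, with a range from 700 nM to 3600 nM, which corresponds to an expected step of a 1.2-fold higher number from compound 3 to compound 4 (0.09 log units; within the scatter).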

Compound 4, half-maximal inhibitory concentration: 2600 nM
The estimate for compound 4 lay 1.6-fold (0.21 log units) below the measured number; measured number inside the range.
By their numbers in this assay, from the lowest: compounds 3, 2, 1 and 4 (each within the scatter of the next).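

Compound 4 carries the only acyclic amine in the set, and with it the series extends beyond ring amines at this place, on a saturated chain carbon, three bonds along the chain from an oxygen on an aromatic ring. In this assay the exchange for dimethylamino gives a 2.0-fold higher number from compound 3 to compound 4 (0.30 log units; within the scatter) and a 1.9-fold higher number from compound 2 to compound 4 (0.27 log units; within the scatter) and also a 1.4-fold higher number from compound 1 to compound 4 (0.14 log units; within the scatter). The first of these is the largest step in the set so far, yet even losing the six-membered non-aromatic ring of 4-methylpiperazin-1-yl, and going from 7 heavy atoms to 3, does not carry the number beyond the scatter, so all four compounds remain one flat stretch with no ranking among them.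

On these data alone, whether a morpholin-4-yl group, an unsubstituted amino group or a carboxylic acid at this place would leave that flat stretch remains open, as does the behaviour of dimethylamino on a longer chain. No measurement is available here that could explain why these amines are so alike in this assay.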